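The compounds below may be only part of what the source reports. "The series", "measured", "known", "first", "only" and "open" are said of these compounds alone.

Working notes on the series. Compound 1 `Clc1ccc2c(O/N=C(/C=C/c3ccc(OCc4ccccc4Cl)cc3)\C=C\c3ccccn3)ncnc2c1` is tested in a functional assay on SMMC-7721 cells (Homo sapiens) for inhibition, read by MTT assay, with a stated time of 72 h, tested at 1 uM (a lower number here means a weaker effect, a higher number a stronger effect of the compound at the concentration tested), and gives 18.1%. Compound 2 `Clc1ccc(COc2ccc(/C=C/C(/C=C/c3ccccn3)=N/Oc3ncnc4ccccc34)cc2)cc1` gives 91.2% in this assay. On the numbers shown, compound 1 stands lowest of the two, and its nearest neighbour, compound 2, lies a long way above it, well beyond the scatter; compound 2 differs from compound 1 in more than one place, so no single step between them is counted, and only the two values are stated here.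

Compound 3 `Fc1ccccc1COc1ccc(/C=C/C(/C=C/c2ccccn2)=N/Oc2ncnc3cc(Cl)ccc23)cc1` is not yet measured. Against compound 1 the difference is fluoro in place of chloro on an aromatic carbon. Among the compounds with values here, no step between measured compounds isolates this change, so nothing in the measured pair tells its size or direction. The expectation is a step in this assay from compound 1 to compound 3 of about a number 6.9 percentage points higher from compound 1 to compound 3 (within the scatter), small and not clearly beyond the scatter. For compound 3 the estimate in this assay is 25%, expected to fall between 5% and 55%.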

Compound 3, a percentage reported as inhibition, at one concentration (the size of the read-out at that concentration, not a potency): 81.1%
For compound 3 the middle estimate is 56.1 percentage points below the measured one, and the stated range ends below it.
By their numbers in this assay, from the lowest: compound 1; then compound 3; then compound 2.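

The step is a number 63 percentage points higher from compound 1 to compound 3 (beyond the scatter) in this assay. The exchange of chloro for fluoro on this aromatic carbon, ortho to a large group, therefore counts for much at the concentration tested: the read-out here is sensitive to the identity of this single halogen, although the change swaps one heavy atom for one heavy atom and involves no ring, hydrogen-bond donor, hydrogen-bond acceptor or net charge. Nothing available bears on the reason for this step.

From the compounds shown here alone, whether hydrogen, a methyl group or a methoxy group on this carbon would stay nearer compound 1 or compound 3 remains open. This one pair also leaves open whether the same exchange of chloro for fluoro would carry a step of similar size elsewhere in the series.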